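The source may report more compounds than this note shows. Statements on the series, on what has been measured and on what is new or still open speak of the compounds shown alone.

Measured compounds in the series:

- compound 1, `ClCc1ccc(Cn2cnc3nc(Cl)nc(Cl)c32)cc1`: 1990 nM
- compound 2, `ClCc1ccccc1Cn1cnc2ncnc(Cl)c21`: 2750 nM

Both numbers come from a functional assay on OVCAR-8 cells (Homo sapiens) for cytotoxicity, read by sulforhodamine B assay, with a stated time of 48 h; on this read-out higher numbers stand for weaker inhibition of growth and lower numbers for stronger inhibition of growth. Among the measured compounds shown here, compound 1 and compound 2 differ in two places at once, in the core and in the benzyl substitution pattern, so no single step links them. On the numbers shown, compound 2 has the higher of the two values, with compound 1 the nearer neighbour; the gap between them is within the usual scatter, so neither compound can be called the stronger inhibitor of growth.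

Compound 3, `ClCc1ccccc1Cn1cnc2nc(Cl)nc(Cl)c21`, is the next compound to be measured. It keeps the benzyl part of compound 2 and changes the core in one place: chloro in place of hydrogen on an aromatic carbon. This brings the core of compound 3 to the same dichloro core found in compound 1.

For the measured compounds named here, no measured step for this change exists here. The two values at hand, compound 1 with the dichloro core and compound 2 with the monochloro core, lie within scatter of each other, which gives no ground to expect a step beyond the scatter in this assay. The step from compound 2 to compound 3 is therefore estimated as small, a 1.3-fold lower number from compound 2 to compound 3 (0.12 log units; within the scatter), if anything toward a lower number. Compound 3 is expected to give 2100 nM in this assay, with a range from 800 nM to 5500 nM.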

Compound 3, concentration for 50% growth inhibition: 2750 nM
The estimate for compound 3 lay 1.3-fold (0.12 log units) below the measured number, within the range that was stated.
By their numbers in this assay, from the lowest: compounds 1, 2 and 3 (each within the scatter of the next).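

In this assay, chloro in place of hydrogen on the aromatic carbon between two ring nitrogen atoms gives no change at the digits printed from compound 2 to compound 3 (within the scatter). Among the compounds shown here, this is the first reading of the series that isolates a single place, as the earlier pair differed in two places at once and could not speak for this position alone. With the benzyl part of compound 2 held fixed, this position tolerates the exchange of hydrogen for chloro on this read-out without a step beyond the scatter, although that rests on this one pair; no evidence bearing on the reason for this outcome is at hand.

From the compounds shown here alone, whether this position stays as flat with a group of another kind, such as an amine or a methoxy group in place of the chloro, remains open. Also open, going by these compounds, is whether the same exchange of hydrogen for chloro reads alike on the benzyl part of compound 1, and whether the chloromethyl group itself matters, which a hydroxymethyl group in its place would test.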